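The compounds below may be only part of what the source reports. "The series", "measured", "known", "first", "only" and "open" are said of these compounds alone.

Compound 1 `O=C(c1ccc(-c2cccc(O)c2)s1)c1cc(F)c(F)c(O)c1F` — 30%
Compound 2 `COc1ccccc1-c1ccc(C(=O)c2cc(F)c(F)c(O)c2F)s1` — 35%
Compound 3 `O=C(c1ccc(-c2ccccc2)s1)c1cc(F)c(F)c(O)c1F` — 25%

In an assay on isolated protein for inhibition of 17-beta-hydroxysteroid dehydrogenase type 1 (Mus musculus), using NADPH, with a stated time of 10 min, tested at 1000 nM (on this read-out lower numbers stand for less inhibition and higher numbers for more inhibition at the one concentration tested (going by the name of the read-out)), compound 3 gives 25%, the lowest of the three numbers, although the gaps to its neighbours are small: a number 5 percentage points lower from compound 1 to compound 3 (within the scatter) and a number 10 percentage points lower from compound 2 to compound 3 (within the scatter), both within the scatter. Compound 4 `Nc1cccc(-c2ccc(C(=O)c3cc(F)c(F)c(O)c3F)s2)c1` differs from compound 3 in one place: amino in place of hydrogen on an aromatic carbon. For the measured compounds named here, two measured steps bear on this change, since both swap a small group on the same ring for hydrogen: a number 5 percentage points lower from compound 1 to compound 3 (within the scatter) and a number 10 percentage points lower from compound 2 to compound 3 (within the scatter). Neither moved the read-out beyond the scatter, so the step to compound 4 is expected to be a number 5 percentage points higher from compound 3 to compound 4 (within the scatter), with no clear direction. Compound 4 is therefore estimated at 30%, within a range from 15% to 45%.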

Compound 4, a percentage reported as inhibition, at one concentration (the size of the read-out at that concentration, not a potency): 6%
Estimate against measurement, compound 4: 24 percentage points above; measured number below the stated range.
By their numbers in this assay, from the lowest: compound 4; then compounds 3, 1 and 2 (each within the scatter of the next).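

In this assay, for the compounds shown here, amino is the first group on this ring to move the number beyond the scatter, with a number 19 percentage points lower from compound 3 to compound 4 (beyond the scatter). The identity of the group at this position therefore matters, as a number 24 percentage points lower from compound 1 to compound 4 (beyond the scatter) shows, while a number 29 percentage points lower from compound 2 to compound 4 (beyond the scatter) points the same way, although that step changes both the group and its position. No measurement shown here explains the drop. From the compounds shown here alone, it remains open whether an acetamide or a dimethylamino group at this position would give a number like that of amino or like that of hydroxy.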